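Pyrimidine for Thiazole on the Urea Nitrogen

The source may hold more compounds than are shown below. What is called first, only, known or untested is meant among the compounds shown, and "the series" means these compounds.

For the measured compounds named here, compound 2 `CC(=O)NN(C(=O)NCc1ccccc1)c1nccs1` is the one compound with an actual number in a functional assay on the whole organism with Mus musculus as the target, in the maximal electroshock model; a lower number here means that less compound is needed, a higher number that more compound is needed for the effect: compound 2 gives 22 mg/kg. Compound 1 `CC(=O)NN(C(=O)NCc1ccccc1)c1ccccc1` reaches only the limit > 30 mg/kg in this assay. The step of an at least 1.3-fold lower number from compound 1 to compound 2 (0.13 log units; that floor lies within the scatter) is the only measured one and, as shown by the limit of > 30 mg/kg in this assay, at which 1 of the 2 values shown sits, its size is known only from its floor. Compound 3 `CC(=O)NN(C(=O)NCc1ccccc1)c1ncccn1` differs from compound 2 by pyrimidin-2-yl in place of 1,3-thiazol-2-yl on an amide-type nitrogen. Going by the values given here, no measured step bears on this change; no direction beyond the scatter is expected, and the step of a 1.3-fold higher number from compound 2 to compound 3 (0.10 log units; within the scatter) is estimated as small. Compound 3 is estimated at 28 mg/kg, expected between 12 mg/kg and 70 mg/kg.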

Compound 3, dose for half-maximal effect: > 100 mg/kg
Compound 3: a limit, no number; the forecaster's own chance of this, stated with the estimate: 40%; middle value at least 3.5-fold (0.55 log units) from the limit.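

In this assay, for the compounds shown here, pyrimidin-2-yl in place of 1,3-thiazol-2-yl on the amide-type nitrogen gives an at least 4.5-fold higher number from compound 2 to compound 3 (0.65 log units; beyond the scatter), the first step at this position to clear the scatter, which the floor of the earlier step did not. Compound 3 stands at a limit, and the step is known only from its floor: the limit of > 100 mg/kg in this assay, at which 1 of the 3 values shown sits. The step between compound 1 and compound 3 cannot be read, as both values are limits.

As far as these compounds go, whether a 1,3-oxazol-2-yl or a pyridin-2-yl group on this nitrogen would give a number rather than a limit remains open.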